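Acetamido to amino on the core of compound 2

A few compounds are considered here, and "the series" means these few. Any claim that something is new, unique, unknown or untested is made for them only; others in the source may bear on it.

Measured compounds in an ADME assay on THP-1 cells (Homo sapiens) for cytotoxicity, read by flow cytometry and propidium iodide staining, with a stated time of 72 h; a higher number here means a weaker inhibitor, a lower number a stronger inhibitor:
compound 1 `CC(=O)Nc1ccc2oc(-c3ccccc3)cc(=O)c2c1` gives 97000 nM
compound 2 `COc1ccc(-c2cc(=O)c3cc(NC(C)=O)ccc3o2)cc1` gives 74000 nM
compound 3 `CC(=O)Nc1ccc2oc(-c3ccc(F)cc3)cc(=O)c2c1` gives 22000 nM

Compound 2 holds the second highest of the three numbers in this assay. Its nearest neighbour is compound 1, and that step, a 1.3-fold lower number from compound 1 to compound 2 (0.12 log units; within the scatter), lies within the scatter, so the two are not separated. Among the compounds with values here, the one step that separates compound 2 from another compound is a 3.4-fold lower number from compound 2 to compound 3 (0.53 log units; beyond the scatter), a modest move to the lower number.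

The next compound, compound 4 `COc1ccc(-c2cc(=O)c3cc(N)ccc3o2)cc1`, differs from compound 2 in one place: hydrogen in place of acetyl on a nitrogen on an aromatic ring.

The three measured steps all sit on an aromatic carbon of the pendant ring: a 1.3-fold lower number from compound 1 to compound 2 (0.12 log units; within the scatter), a 4.4-fold lower number from compound 1 to compound 3 (0.64 log units; beyond the scatter) and a 3.4-fold lower number from compound 2 to compound 3 (0.53 log units; beyond the scatter). Within the data shown here, none of them touches the nitrogen where the acetyl leaves and hydrogen enters, so no measured step bears directly on this change. The series therefore gives no ground for expecting a move beyond the scatter in this assay in either direction. The expected step is a 1.2-fold lower number from compound 2 to compound 4 (0.09 log units; within the scatter). Compound 4 is accordingly estimated at 60000 nM, with a range from 20000 nM to 150000 nM.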

Compound 4, half-maximal inhibitory concentration: 124000 nM
Compound 4: the middle estimate sits 2.1-fold (0.32 log units) below what was measured, within the range that was stated.
By their numbers in this assay, from the lowest: compound 3; then compounds 2, 1 and 4 (each within the scatter of the next).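

In this assay, the first step read at this nitrogen on an aromatic ring is a 1.7-fold higher number from compound 2 to compound 4 (0.22 log units; within the scatter), so the acetamido and amino forms of the core carrying methoxy on the pendant ring are not separated. The earlier steps shown here all lay on the pendant ring, and this one shows that the acetyl, with its 3 heavy atoms and its hydrogen-bond acceptor, can leave this position without a move beyond the scatter. Nothing measured here bears on the reason for this result.

On these data alone, whether acetamido to amino reads the same with other groups on the pendant ring stays open, including the fluoro of compound 3, which gives 22000 nM and holds the lowest number of the series. Also open, as far as these compounds go, is whether a longer acyl chain such as propionyl, a methanesulfonyl group or a dimethylamino group at this nitrogen would stay within the scatter of compound 2 in this assay or move beyond it in either direction.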